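The source may report more compounds than this note shows. Statements on the series, on what has been measured and on what is new or still open speak of the compounds shown alone.

Two compounds have numbers in a functional assay on A549 cells (Homo sapiens) for antiproliferative activity, read by MTT assay, with a stated time of 48 h; on this read-out higher numbers stand for weaker inhibition and lower numbers for stronger inhibition. Compound 1 `COc1ccc(-c2nn(-c3ccccc3)cc2C(=O)/C=C\Nc2cc(OC)c(OC)c(OC)c2)cc1` gives 11200 nM there, and compound 2 `COc1cc(-c2nn(-c3ccccc3)cc2C(=O)/C=C\Nc2ccc(Cl)cc2)cc(OC)c1OC` gives 8670 nM; the two numbers sit within the scatter of each other, so compound 2 stands level with compound 1. Compound 3 `COc1cc(N/C=C\C(=O)c2cn(-c3ccccc3)nc2-c2cc(OC)c(OC)c(OC)c2)cc(OC)c1OC` carries 3,4,5-trimethoxyphenyl in place of 4-chlorophenyl on an amine nitrogen. Within the data shown here, no step between measured compounds covers this change, so in this assay nothing beyond the scatter is expected from compound 2 to compound 3, at most a slight lean toward a lower number. Compound 3 is therefore estimated at 7000 nM, within 2500 nM to 20000 nM, an expected step of a 1.2-fold lower number from compound 2 to compound 3 (0.09 log units; within the scatter).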

Compound 3, half-maximal inhibitory concentration: 7980 nM
Compound 3: middle estimate off by 1.1-fold (0.06 log units), on the low side, and the stated range covers the measured number.
By their numbers in this assay, from the lowest: compounds 3, 2 and 1 (each within the scatter of the next).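

In this assay, 3,4,5-trimethoxyphenyl in place of 4-chlorophenyl on an amine nitrogen gives a 1.1-fold lower number from compound 2 to compound 3 (0.04 log units; within the scatter) and so leaves the two compounds level, even though the entering group carries three methoxy groups and no chlorine. On an aromatic carbon, 3,4,5-trimethoxyphenyl in place of 4-methoxyphenyl gives a 1.4-fold lower number from compound 1 to compound 3 (0.15 log units; within the scatter) and likewise separates nothing. No measurement at hand bears on the reason for either result. Still open, going by these compounds, is whether a carboxylic acid, an amine or a longer chain on that amine nitrogen would give a step beyond the scatter. The same question stands for such groups on the aromatic carbon.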